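The source may report more compounds than this note shows. Statements on the series, on what has been measured and on what is new or still open speak of the compounds shown alone.

In a functional assay on MCF-10A cells (Homo sapiens) for antiproliferative activity, with a stated time of 48 h (on this read-out higher numbers stand for an effect only at larger amounts of compound and lower numbers for an effect already at smaller amounts), two compounds have been measured so far:

Compound 1 `COc1ccc2nc(C)cc(NCc3ccccc3)c2c1`: 28600 nM
Compound 2 `COc1ccc2nc(C)cc(NCc3ccc(C)cc3)c2c1`: 22400 nM

Compound 2 has the lower of these two numbers, but its value lies within the usual scatter of the value for compound 1, so the pair cannot be ranked. The next compound, compound 3 `COc1ccc2nc(C)cc(NCc3ccc(OC(F)F)cc3)c2c1`, carries difluoromethoxy in place of the methyl of compound 2, on an aromatic carbon para to a large group (difluoromethoxy in place of methyl on an aromatic carbon).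

For the measured compounds named here, only one measured step bears on this change. It is methyl in place of hydrogen on an aromatic carbon, and it amounts to a 1.3-fold lower number from compound 1 to compound 2 (0.11 log units; within the scatter). Going by the values given here, no measured compound yet carries difluoromethoxy, so this small step is a weak guide to the new group. With nothing pointing either way, no direction is expected in this assay, and the expected change is no larger than the scatter: a 1.1-fold lower number from compound 2 to compound 3 (0.05 log units; within the scatter). The range is kept wide to reflect how little the data show. For compound 3 the estimated value is 20000 nM, with an expected range from 8000 nM to 50000 nM.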

Compound 3, half-maximal effective concentration: 14700 nM
Estimate against measurement, compound 3: 1.4-fold (0.13 log units) above, within the range that was stated.
By their numbers in this assay, from the lowest: compounds 3, 2 and 1 (each within the scatter of the next).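

In this assay, the aromatic carbon para to a large group now has three substituents to compare, and difluoromethoxy in place of methyl gives a 1.5-fold lower number from compound 2 to compound 3 (0.18 log units; within the scatter), a step that lies within the scatter. Difluoromethoxy in place of hydrogen gives a 1.9-fold lower number from compound 1 to compound 3 (0.29 log units; within the scatter), which is also within the scatter, so neither step separates the compounds and the three cannot be ranked. What the earlier pair could not show is that difluoromethoxy, with 4 heavy atoms and 1 hydrogen-bond acceptor against the 1 heavy atom and no acceptor of methyl, can occupy this place with the number still within the scatter of those for the methyl and hydrogen compounds. No measurement is available that would explain these numbers.

As far as these compounds go, it remains open whether any group on this aromatic carbon can move the number beyond the scatter, for instance an amine, a carboxylic acid or a longer chain. From the compounds shown here alone, it is also open whether difluoromethoxy would give a similar result on the same ring at a place other than this one.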